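A few compounds are considered here, and "the series" means these few. Any claim that something is new, unique, unknown or untested is made for them only; others in the source may bear on it.

Going by the values given here, compound 2 `Cc1ccc(-n2nccn2)c(C(=O)N2C[C@H](C#Cc3cccnc3O)CC[C@H]2C)c1` stands as the stronger binder of the two compounds measured so far. In an assay on cells for binding affinity to Orexin/Hypocretin receptor type 1 (Homo sapiens), read by radioligand binding (a higher number here means a weaker inhibitor, a lower number a stronger inhibitor), compound 2 gives 24 nM, while compound 1 `Cc1ccc(-n2nccn2)c(C(=O)N2C[C@H](C#Cc3ccc(CO)cn3)CC[C@H]2C)c1` gives 211 nM. Among the compounds with values here, the single measured step, an 8.8-fold lower number from compound 1 to compound 2 (0.94 log units; beyond the scatter), arose from swapping the group on the triple-bonded carbon. Compound 3 `Cc1ccc(-n2nccn2)c(C(=O)N2C[C@H](C#Cc3ccc(F)cn3)CC[C@H]2C)c1` alters that same position once more: 5-fluoropyridin-2-yl in place of 2-hydroxypyridin-3-yl on a triple-bonded carbon. The 5-fluoropyridin-2-yl of compound 3 shares its ring attachment with the 5-(hydroxymethyl)pyridin-2-yl of compound 1, so compound 3 sits closer in shape to compound 1 than to compound 2. Going by these compounds, only an 8.8-fold lower number from compound 1 to compound 2 (0.94 log units; beyond the scatter) bears on this change, and since compound 3 moves back toward the group of compound 1, the number is expected to rise again, though the fluorine is untested here. For compound 3 the estimate in this assay is 110 nM, with a range from 30 nM to 400 nM. This corresponds to an expected step of a 4.6-fold higher number from compound 2 to compound 3 (0.66 log units; beyond the scatter).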

Compound 3, inhibition constant: 1.1 nM
Estimate against measurement, compound 3: 100-fold (2.00 log units) above; the measured number lies below the stated range.
By their numbers in this assay, from the lowest: compound 3; then compound 2; then compound 1.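

In this assay, the group on the triple-bonded carbon can shift the number much further than the first pair showed, and 5-fluoropyridin-2-yl in place of 2-hydroxypyridin-3-yl gives a 22-fold lower number from compound 2 to compound 3 (1.34 log units; beyond the scatter) even though that swap alters the ring's attachment and its substituent together. The cleaner comparison keeps the ring attachment and changes one group, fluoro in place of hydroxymethyl on an aromatic carbon, and it gives a 190-fold lower number from compound 1 to compound 3 (2.28 log units; beyond the scatter) so the substituent alone can move the number a long way. Nothing available here explains why fluoro gives the lower number.

Going by these compounds, it remains open whether fluoro is specifically needed, or whether a chloro, methoxy or nitrile group in its place would do as well. Going by these compounds alone, how much the ring's attachment counts by itself also remains unsettled, since no pair here changes only that.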